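This account rests on a few compounds, and the source may have more. Where it says the series, first, only, none or still open, it means among the compounds named here.

Compound 1 `COc1ccc(C)cc1NC(=S)N/N=C/c1ccc2ccccc2n1` was examined in a functional assay on HeLa cells (Homo sapiens) for antiproliferative activity, read by sulforhodamine B assay, with a stated time of 72 h; on this read-out lower numbers stand for stronger inhibition and higher numbers for weaker inhibition. In this assay compound 1 returns only a limit, > 100000 nM, and that figure is a limit of the measurement rather than a number. Where compound 1 stands among the values shown is therefore given by the limit of > 100000 nM in this assay, at which 1 of the 2 values shown sits. For the measured compounds named here, a second compound, compound 2 `CN(C)C(=S)N/N=C/c1ccc2cccnc2n1`, built on a different core, gives 970 nM in this assay; no step between compound 1 and compound 2 is drawn here, so the two values simply stand side by side.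

Compound 3 `Cc1cccc(NC(=S)N/N=C/c2ccc3ccccc3n2)c1` differs from compound 1 in one place: hydrogen in place of methoxy on an aromatic carbon, in words hydrogen in place of methoxy on an aromatic carbon, ortho to a large group and para to a methyl group. No measured step of this kind exists among the compounds shown. Since the rest of compound 1 is kept, a shift of no more than the usual scatter is expected from compound 1 to compound 3, and the step of an at least 1.2-fold lower number from compound 1 to compound 3 (0.09 log units; that floor lies within the scatter) is judged to stay within that scatter. For compound 3 in this assay the estimate is 80000 nM, with a range from 20000 nM to 300000 nM, and a limit again seems the likeliest report.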

Compound 3, half-maximal inhibitory concentration: > 100000 nM
Compound 3: only a limit was reported (the forecaster's own chance of this, stated with the estimate: 60%); middle value at least 1.2-fold (0.09 log units) from the limit.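

Compound 1 and compound 3 each return only a limit in this assay, so the step between them cannot be read: the limit of > 100000 nM in this assay, at which 2 of the 3 values shown sit.

The compounds shown leave open how far hydrogen in place of methoxy on an aromatic carbon shifts the activity of the core of compound 1, in either direction, and what number lies behind either limit.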